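Thiadiazole amide series: chain variation at the aminothiadiazole nitrogen

The source may report more compounds than this note shows. Statements on the series, on what has been measured and on what is new or still open speak of the compounds shown alone.

Of the compounds shown here, three of the shared core have been measured in an assay on isolated protein for inhibition of Amine oxidase [flavin-containing] A (Homo sapiens), read by fluorescence and Amplex Red, with a stated time of 30 min, tested at 0.01 nM; a lower number here means a weaker effect, a higher number a stronger effect of the compound at the concentration tested. Compound 1 `CCCNc1nnc(SCC(=O)N(Cc2cccc([N+](=O)[O-])c2)c2ccc(F)cc2)s1` gives 8.5%. Compound 2 `CC(C)CNc1nnc(SCC(=O)N(Cc2cccc([N+](=O)[O-])c2)c2ccc(F)cc2)s1` gives 6.36%. Compound 3 `C=CCNc1nnc(SCC(=O)N(Cc2cccc([N+](=O)[O-])c2)c2ccc(F)cc2)s1` gives 10.3%. Compound 3 holds the highest of the three numbers, yet its steps to both others fall within the scatter: a number 1.8 percentage points higher from compound 1 to compound 3 (within the scatter) and a number 3.9 percentage points higher from compound 2 to compound 3 (within the scatter). The branching step a number 2.1 percentage points lower from compound 1 to compound 2 (within the scatter) is likewise within the scatter. Nothing in this set separates the three chains on the aminothiadiazole nitrogen.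

Compound 4 `CCNc1nnc(SCC(=O)N(Cc2cccc([N+](=O)[O-])c2)c2ccc(F)cc2)s1` has not yet been measured in this assay. It differs from compound 3 as follows: methyl in place of vinyl on a saturated chain carbon bound to a nitrogen on an aromatic ring. Among the compounds with values here, the steps that bear on this change are those at the same place, from compound 1 to compound 3 and from compound 2 to compound 3, both small and within the scatter. A step beyond the scatter in this assay is therefore not expected in either direction; the estimated step of a number 1.3 percentage points lower from compound 3 to compound 4 (within the scatter) is expected to stay within the scatter. For compound 4 the value in this assay is estimated at 9%, with a range from 2% to 16%.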

Compound 4, a percentage reported as inhibition, at one concentration (the size of the read-out at that concentration, not a potency): 10.3%
For compound 4 the middle estimate is 1.3 percentage points below the measured one; the range from low to high includes it.
By their numbers in this assay, from the lowest: compounds 2, 1, 3 and 4 (each within the scatter of the next).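

With the ethyl chain of compound 4 in hand, the four chains at this position still cannot be told apart in this assay: no change at the digits printed from compound 3 to compound 4 (within the scatter), a number 1.8 percentage points higher from compound 1 to compound 4 (within the scatter) and a number 3.9 percentage points higher from compound 2 to compound 4 (within the scatter). The swap of allyl for ethyl removes the double bond outside aromatic rings without a step beyond the scatter, so a read-out of this size does not depend on that double bond. No available evidence explains why these chains read alike.

Going by these compounds, whether a longer chain, a cyclohexyl ring, a benzyl group or a chain ending in a carboxylic acid on this nitrogen would give a step beyond the scatter stays open. With a single tested concentration, any difference in potency among these four chains also remains unresolved.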